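A few compounds are considered here, and "the series" means these few. Any claim that something is new, unique, unknown or untested is made for them only; others in the source may bear on it.

Measured compounds:
compound 1 `COc1cccc(CNCCCNc2ccnc3cc(Oc4ccc(Cl)cc4)ccc23)c1O` gives 317 10^-6 cm/s in an ADME assay for permeability, using PAMPA, with a stated time of 30 min, at pH 7.4; a higher number here means that the compound crosses the layer faster, a lower number that the compound crosses the layer more slowly;
compound 2 `COc1ccc(F)cc1CNCCCNc1ccnc2cc(C3CCCCC3)ccc12` gives 23 10^-6 cm/s in this assay.

Among the measured compounds shown here, compound 1 stands highest of the two numbers, with compound 2 as its only neighbour, a gap beyond the usual scatter. Compound 3 `COc1cccc(CNCCCNc2ccnc3cc(CC4CCCCC4)ccc23)c1O` carries one change from compound 1: cyclohexylmethyl in place of 4-chlorophenoxy on an aromatic carbon. For the measured compounds named here, no step between measured compounds covers this change, so the size of the step is uncertain; a moderate drop in this assay is expected, but not one beyond what compound 2 shows with 23 10^-6 cm/s. Compound 3 is estimated at 150 10^-6 cm/s, within 50 10^-6 cm/s to 350 10^-6 cm/s, a step of a 2.1-fold lower number from compound 1 to compound 3 (0.32 log units; beyond the scatter).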

Compound 3, apparent permeability: 23 10^-6 cm/s
The estimate for compound 3 lay 6.5-fold (0.81 log units) above the measured number, outside the stated range (below it).
By their numbers in this assay, from the lowest: compounds 2 and 3 (each within the scatter of the next); then compound 1.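

In this assay, the exchange of 4-chlorophenoxy for cyclohexylmethyl on this aromatic carbon gives a large step, a 14-fold lower number from compound 1 to compound 3 (1.14 log units; beyond the scatter), with the rest of compound 1 unchanged. This shows that the read-out depends strongly on the group at this position. Nothing given here accounts for the size of the step. Still open, on these data alone, is which part of the change carries the step: the oxygen, the chlorine or the aromatic ring. A benzyl group or an unsubstituted phenoxy at this carbon would begin to separate these.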